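One methoxyphenyl for another on the shared core

A few compounds are considered here, and "the series" means these few. Any claim that something is new, unique, unknown or untested is made for them only; others in the source may bear on it.

Of the compounds shown here, three built on one shared core have been tested in a functional assay on PC-3 cells (Homo sapiens) for cytotoxicity, read by MTT assay, with a stated time of 72 h; a lower number here means a stronger inhibitor, a higher number a weaker inhibitor. Compound 1 `CCCCCCCCCCCCNc1nc(SCc2ccc(C(F)(F)F)cc2)nc2ccccc12` gives 26000 nM in this assay. Compound 2 `COc1ccccc1Nc1nc(SCc2ccc(C(F)(F)F)cc2)nc2ccccc12` gives 14100 nM, and compound 3 `FC(F)(F)c1ccc(CSc2nc(Nc3ccc(C(F)(F)F)cc3)c3ccccc3n2)cc1` gives 7880 nM. Compound 2 sits within the usual scatter of both companions: the step of a 1.8-fold lower number from compound 2 to compound 3 (0.25 log units; within the scatter) is small, and the gap between compound 2 and compound 1 is also within the scatter, so on these numbers none of the three can be told apart from the others.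

Compound 4 `COc1ccc(Nc2nc(SCc3ccc(C(F)(F)F)cc3)nc3ccccc23)cc1` has not yet been measured. It differs from compound 2 in one place: 4-methoxyphenyl in place of 2-methoxyphenyl on a nitrogen on an aromatic ring. Among the compounds with values here, the only measured step at this nitrogen is the one in which 4-(trifluoromethyl)phenyl took the place of 2-methoxyphenyl, and that larger swap left the number within the scatter. A smaller rearrangement of the same group is therefore expected to give no step beyond the scatter in this assay, that is, a 1.2-fold lower number from compound 2 to compound 4 (0.07 log units; within the scatter). Compound 4 is accordingly estimated at 12000 nM, with a range from 5000 nM to 30000 nM.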

Compound 4, half-maximal inhibitory concentration: 16700 nM
The estimate for compound 4 lay 1.4-fold (0.14 log units) below the measured number; the measured number falls inside the stated range.
By their numbers in this assay, from the lowest: compounds 3, 2, 4 and 1 (each within the scatter of the next, the first and the last beyond it).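

Moving the methoxy group, with 4-methoxyphenyl in place of 2-methoxyphenyl on the nitrogen, gives a 1.2-fold higher number from compound 2 to compound 4 (0.07 log units; within the scatter), so in this assay these two placements cannot be told apart. Within the data shown here, exchanging one group for another at the same place on the ring tells more: methoxy in place of trifluoromethyl on an aromatic carbon gives a 2.1-fold higher number from compound 3 to compound 4 (0.33 log units; beyond the scatter), a modest step but the only one between compounds differing in one place that lies beyond the scatter. Nothing available explains either step.

Going by these compounds, whether a chlorine atom, a hydroxyl group or a dimethylamino group on this phenyl ring would shift the number further remains open. On these data alone, it is also open whether a phenyl ring with no added group at all would differ from compound 3 or compound 4.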